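Swapping the Amine Substituent: Expected Cytotoxicity of Compound 3

The source may hold more compounds than are shown below. What is called first, only, known or untested is meant among the compounds shown, and "the series" means these compounds.

Compound 1 `CCN(CC)Cc1c(O)ccc2oc(Cc3ccccc3)cc12`: 12000 nM
Compound 2 `CN(Cc1c(O)ccc2oc(Cc3ccccc3)cc12)C1CCCCC1`: 12000 nM

In a functional assay on SQ20B cells (Homo sapiens) for cytotoxicity, read by MTT assay, with a stated time of 72 h (a higher number here means a weaker inhibitor, a lower number a stronger inhibitor), compound 1 stands level with compound 2 at the digits shown. Going by the values given here, the only measured step, which also exchanges the amine on the saturated chain carbon bound to an aromatic carbon, reads no change at the digits printed from compound 1 to compound 2 (within the scatter). Compound 3 `Oc1ccc2oc(Cc3ccccc3)cc2c1CN1CCCC(O)C1` differs from compound 1 by 3-hydroxypiperidin-1-yl in place of diethylamino on a saturated chain carbon bound to an aromatic carbon. Since the comparable exchange gave no change at the digits printed from compound 1 to compound 2 (within the scatter), the step to compound 3 is expected to be no change at the digits printed from compound 1 to compound 3 (within the scatter), nothing beyond the scatter. Compound 3 is therefore estimated at 12000 nM, within 5000 nM to 28000 nM.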

Compound 3, half-maximal inhibitory concentration: 11000 nM
Compound 3: middle estimate off by 1.1-fold (0.04 log units), on the high side, within the range that was stated.
By their numbers in this assay, from the lowest: compounds 3, 1 and 2 (each within the scatter of the next).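

In this assay, the exchange for 3-hydroxypiperidin-1-yl on a saturated chain carbon bound to an aromatic carbon reads a 1.1-fold lower number from compound 1 to compound 3 (0.04 log units; within the scatter) and a 1.1-fold lower number from compound 2 to compound 3 (0.04 log units; within the scatter). The position therefore gives matching readings for two open amines and for a six-membered non-aromatic ring carrying a hydrogen-bond donor, which diethylamino lacks. No supporting data explain these readings. The compounds shown leave open whether a carboxylic acid or a morpholin-4-yl group at this place would read the same.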